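The source may hold more compounds than are shown below. What is called first, only, known or untested is meant among the compounds shown, and "the series" means these compounds.

Measured so far:
compound 1 `Cc1ccc(-c2cn(-c3ccnc4cc(Cl)ccc34)nn2)cc1` — 352000 nM
compound 2 `CC(C)(O)c1cn(-c2ccnc3cc(Cl)ccc23)nn1` — 442000 nM
compound 3 `Clc1ccc2c(-n3cc(C4CCCCC4)nn3)ccnc2c1` — > 3200 nM

In an ADME assay on HepG2 cells (Homo sapiens) for cytotoxicity, read by MTT assay, with a stated time of 24 h (on this read-out lower numbers stand for higher toxicity in this test and higher numbers for lower toxicity in this test), compound 1 gives 352000 nM and compound 2 gives 442000 nM; the step of a 1.3-fold higher number from compound 1 to compound 2 (0.10 log units; within the scatter) separates them, so the two sit together. Compound 3 is different: in this assay compound 3 shows only a limit, > 3200 nM. Because of the limit of > 3200 nM in this assay, at which 1 of the 3 values shown sits, the steps a step that the limit leaves unreadable from compound 1 to compound 3 and a step that the limit leaves unreadable from compound 2 to compound 3 stay unreadable, and compound 3 therefore has no fixed place on the numbers shown, only a floor.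

Compound 4 `CCN(CC)Cc1cn(-c2ccnc3cc(Cl)ccc23)nn1` takes the next step: (diethylamino)methyl in place of cyclohexyl on an aromatic carbon. Going by the values given here, no measured step touches the cyclohexyl group with a readable size, and the one readable step, a 1.3-fold higher number from compound 1 to compound 2 (0.10 log units; within the scatter), concerns other groups and lies within the scatter. The expectation for compound 4 in this assay therefore rests on compounds 1 and 2 rather than on compound 3, and the step that the limit leaves unreadable from compound 3 to compound 4 is only an estimate measured from a limit. Compound 4 is expected to give about 250000 nM in this assay, with a range from 40000 nM to 1000000 nM.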

Compound 4, half-maximal cytotoxic concentration: 1850000 nM
Beside the measured number, compound 4's estimate is 7.4-fold (0.87 log units) below it, outside the stated range (above it).
By their numbers in this assay, from the lowest: compounds 1 and 2 (each within the scatter of the next); then compound 4.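

At this position of the shared core, this assay now shows a change beyond the scatter: a 4.2-fold higher number from compound 2 to compound 4 (0.62 log units; beyond the scatter), and a 5.3-fold higher number from compound 1 to compound 4 (0.72 log units; beyond the scatter). Both steps point towards lower toxicity in this test, so the group on this aromatic carbon can move the number, which the step between compounds 1 and 2 did not show. The step from compound 3 to compound 4 cannot be read, because compound 3 has only a limit and not a number: the limit of > 3200 nM in this assay, at which 1 of the 4 values shown sits.

The compounds shown leave open whether the rise goes with the nitrogen of the (diethylamino)methyl group or with its open chain. A plain pentyl chain, which has no nitrogen, or a morpholine ring, which holds its nitrogen in a ring, on the same carbon would help separate the two.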